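This account rests on a few compounds, and the source may have more. Where it says the series, first, only, none or still open, it means among the compounds named here.

Measured so far in a physicochemical assay for lipophilicity; on this read-out lower numbers stand for lower lipophilicity and higher numbers for higher lipophilicity:
- compound 1 `CNC(=O)c1cc(C(=O)N[C@H]2CC[C@H](O)CC2)c([C@@H](C)c2cccc(C)c2)o1` gives 3.3
- compound 2 `CNC(=O)c1cc(C(=O)N[C@H]2[C@@H]3COC[C@@H]32)c([C@@H](C)c2ccccc2)o1` gives 4.1
- compound 3 `CNC(=O)c1cc(C(=O)NC2CCOCC2)n([C@@H](C)c2ccccc2)n1` gives 3.6

Compound 3 stands second highest of the three numbers. Its nearest neighbour is compound 1, whose value 3.3 lies within the usual scatter of that of compound 3, so no order between these two can be read. Compound 2 is furthest away, with 4.1 beyond the scatter above compound 3. Among the compounds with values here, none of the measured pairs differs in a single place, so no step that isolates one change is available from the numbers above.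

The next compound, compound 4 `CNC(=O)c1cc(C(=O)NC(C)CO)n([C@@H](C)c2ccccc2)n1`, is built from compound 3 by one change: 1-(hydroxymethyl)ethyl in place of oxan-4-yl on an amide-type nitrogen. Nothing in the three measured compounds isolates this change, so the expectation rests only on the value of compound 3, 3.6, and on what is counted in the difference.

For compound 4 a downward step in this assay of a number 0.70 log units lower from compound 3 to compound 4 (beyond the scatter) is expected, clearly beyond the scatter. Compound 4 is therefore estimated at 2.9, within the range 2.4 to 3.4.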

Compound 4, distribution coefficient: 2.8
For compound 4 the middle estimate is 0.10 log units above the measured one; the range from low to high includes it.
By their numbers in this assay, from the lowest: compound 4; then compounds 1 and 3 (each within the scatter of the next); then compound 2.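

Within the data shown here, at the amide-type nitrogen, the exchange of oxan-4-yl for 1-(hydroxymethyl)ethyl gives the first isolated step: in this assay it reads as a number 0.80 log units lower from compound 3 to compound 4 (beyond the scatter). The read-out therefore responds to the group at this position, at least on the core shared by these two compounds. The exchange alters several counted features together, replacing a six-membered non-aromatic ring of 6 heavy atoms with a group of 4 heavy atoms and no ring, and adding 1 hydrogen-bond donor, while the hydrogen-bond acceptor count stays at 1 and neither group carries a net charge; no supporting measurement here apportions the step among these features or explains it.

Still open, on these data alone, is how much of the step follows the hydroxyl and how much the loss of the ring; a plain isopropyl group on the same nitrogen, with the ring gone and no hydroxyl, would separate the two. Also open, as far as these compounds go, is how a 1-(aminomethyl)ethyl group, with an amine in place of the hydroxyl, would read at this position.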